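Kallikrein-7 inhibitors: varying the benzyl ring substituents

A few compounds are considered here, and "the series" means these few. Any claim that something is new, unique, unknown or untested is made for them only; others in the source may bear on it.

Measured so far:
compound 1 `Cc1cccc(Cl)c1CC1CN/C(=N\N(C)C)CN(CC(=O)Nc2cccc(-c3cnn(C)c3)c2)C1=O`: 1500 nM
compound 2 `CN(C)/N=C1/CN(CC(=O)Nc2cccc(-c3cnn(C)c3)c2)C(=O)C(Cc2c(F)cccc2F)CN1`: 6900 nM
compound 3 `CN(C)/N=C1/CN(CC(=O)Nc2cccc(-c3cnn(C)c3)c2)C(=O)C(Cc2c(F)cccc2C(F)(F)F)CN1`: 2700 nM

In an assay on isolated protein for inhibition of kallikrein-7 (Homo sapiens), read by fluorescence, with stated times of 10 min and 30 min (a higher number here means a weaker inhibitor, a lower number a stronger inhibitor), compound 3 sits between the other two: the step of a 1.8-fold higher number from compound 1 to compound 3 (0.26 log units; within the scatter) stays within the scatter, whereas the step of a 2.6-fold lower number from compound 2 to compound 3 (0.41 log units; beyond the scatter) lies beyond it. Compound 4 `CN(C)/N=C1/CN(CC(=O)Nc2cccc(-c3cnn(C)c3)c2)C(=O)C(Cc2c(F)cccc2Cl)CN1` carries chloro in place of trifluoromethyl on an aromatic carbon. The steps of a 4.6-fold higher number from compound 1 to compound 2 (0.66 log units; beyond the scatter) and a 2.6-fold lower number from compound 2 to compound 3 (0.41 log units; beyond the scatter) show that swapping groups on this ring shifts this assay only modestly, and compound 4 lies between compound 2 and compound 3 in what it carries there. A step of roughly a 1.2-fold higher number from compound 3 to compound 4 (0.07 log units; within the scatter) is therefore expected, essentially none beyond the scatter. Compound 4 is estimated at 3200 nM in this assay, within a range of 1500 nM to 7000 nM.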

Compound 4, half-maximal inhibitory concentration: 940 nM
Beside the measured number, compound 4's estimate is 3.4-fold (0.53 log units) above it; measured number outside the range, below it.
By their numbers in this assay, from the lowest: compounds 4, 1 and 3 (each within the scatter of the next, the first and the last beyond it); then compound 2.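

In this assay, chloro on this aromatic carbon gives a lower number than both trifluoromethyl (a 2.9-fold lower number from compound 3 to compound 4 (0.46 log units; beyond the scatter)) and fluoro (a 7.3-fold lower number from compound 2 to compound 4 (0.87 log units; beyond the scatter)), so the earlier step from fluoro to trifluoromethyl did not set a trend across these groups. With chloro in place, fluoro and methyl cannot be told apart (a 1.6-fold lower number from compound 1 to compound 4 (0.20 log units; within the scatter)). Nothing available explains these differences.

Still open, going by these compounds, is how a methoxy group or an amine on this aromatic carbon would compare with chloro. Also open, on these data alone, is whether a second chloro in place of the remaining fluoro would lower the number further.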